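The source may report more compounds than this note shows. Statements on the series, on what has been measured and on what is new or still open speak of the compounds shown alone.

In an ADME assay on HEK-293T cells (Homo sapiens) for cytotoxicity, read by MTT assay, with a stated time of 24 h (a lower number here means that less compound is tolerated, a higher number that more compound is tolerated), compound 1 (`Cc1ccc(-c2nn(-c3ccccc3)cc2-c2nc3ccccc3[nH]2)cc1`) gives 187000 nM as its value, compound 2 (`Cc1ccc(-c2nn(-c3ccccc3)cc2-c2nc3ccccc3n2S(=O)(=O)c2cc(C)ccc2C)cc1`) gives 82200 nM and compound 3 (`Cc1ccc(-c2nn(-c3ccccc3)cc2-c2nc3ccccc3n2S(=O)(=O)c2ccc(Cl)cc2)cc1`) gives 167000 nM on the same read-out. The (4-chlorophenyl)sulfonyl group leaves the number within the scatter (a 1.1-fold lower number from compound 1 to compound 3 (0.05 log units; within the scatter)), while the (2,5-dimethylphenyl)sulfonyl group moves it modestly (a 2.3-fold lower number from compound 1 to compound 2 (0.36 log units; beyond the scatter)). Compound 3 therefore stands level with compound 1 and modestly clear of compound 2 (a 2.0-fold higher number from compound 2 to compound 3 (0.31 log units; beyond the scatter)).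

Compound 4 (`Cc1ccc(-c2nn(-c3ccccc3)cc2-c2nc3ccccc3n2S(=O)(=O)c2ccc(Br)cc2)cc1`) has bromo in place of chloro on an aromatic carbon, para to a large group (bromo in place of chloro on an aromatic carbon). Within the data shown here, no measured step exchanges one halogen for another. The closest evidence is the change on the sulfonyl sulfur (a 2.0-fold higher number from compound 2 to compound 3 (0.31 log units; beyond the scatter)), which is only modest although a differently substituted phenyl enters there, so no step beyond the scatter is expected in this assay for this smaller exchange. The estimated step is small (a 1.1-fold lower number from compound 3 to compound 4 (0.05 log units; within the scatter)) and lies within the scatter. Compound 4 is expected at 150000 nM (estimated range 75000 nM to 300000 nM).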

Compound 4, half-maximal cytotoxic concentration: 159000 nM
Compound 4: middle estimate off by 1.1-fold (0.03 log units), on the low side, within the range that was stated.
By their numbers in this assay, from the lowest: compounds 2, 4, 3 and 1 (each within the scatter of the next, the first and the last beyond it).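

In this assay, among these compounds, the first halogen exchange at this place, on an aromatic carbon para to a large group, stays within the scatter (a 1.1-fold lower number from compound 3 to compound 4 (0.02 log units; within the scatter)). Set against hydrogen on the aromatic nitrogen, the (4-bromophenyl)sulfonyl group also stays within the scatter (a 1.2-fold lower number from compound 1 to compound 4 (0.07 log units; within the scatter)), as the (4-chlorophenyl)sulfonyl group did. Against 2,5-dimethylphenyl on the sulfonyl sulfur, 4-bromophenyl gives a step within the scatter (a 1.9-fold higher number from compound 2 to compound 4 (0.29 log units; within the scatter)), whereas 4-chlorophenyl gave one just beyond it, so the separation of compound 2 from the two halogen compounds is not firm.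

No supporting data bear on why these numbers fall as they do. From the compounds shown here alone, whether an amine or a carboxylic acid at this same place would also stay within the scatter remains open.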